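Working notes: one substituent swap, two ring positions

This account rests on a few compounds, and the source may have more. Where it says the series, first, only, none or still open, it means among the compounds named here.

Measured in a functional assay on VCaP cells (Homo sapiens) for antiproliferative activity, read by fluorescence and propidium iodide staining, with a stated time of 96 h; a higher number here means a weaker inhibitor, a lower number a stronger inhibitor:

Compound 1, `O=C(Nc1ccc(S(F)(F)(F)(F)F)cc1)c1ccc(S(=O)(=O)c2ccc(O)cc2)cc1`, gives 5350 nM.
Compound 2, `O=C(Nc1cccc(S(F)(F)(F)(F)F)c1)c1ccc(S(=O)(=O)c2ccc(O)cc2)cc1`, gives 10800 nM.
Compound 3, `O=C(Nc1ccc(C(F)(F)F)cc1)c1ccc(S(=O)(=O)c2ccc(O)cc2)cc1`, gives 27200 nM.

Compound 1 and compound 2 are built from the same atoms joined differently; the difference between the two cores is not broken down here. What the values show is that compound 2 sits higher than compound 1 and lower than compound 3, both gaps beyond the scatter.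

Going by the values given here, the only change measured in the set is a group of 4 heavy atoms (1 carbon, 3 fluorine; no ring) in place of a group of 6 heavy atoms (5 fluorine, 1 sulfur; no ring), on an aromatic carbon, which gives a 5.1-fold higher number from compound 1 to compound 3 (0.71 log units; beyond the scatter). Compound 4, `O=C(Nc1cccc(C(F)(F)F)c1)c1ccc(S(=O)(=O)c2ccc(O)cc2)cc1`, is not yet measured; it carries the same kind of change relative to compound 2, namely (a group of 4 heavy atoms (1 carbon, 3 fluorine; no ring) in place of a group of 6 heavy atoms (5 fluorine, 1 sulfur; no ring), on an aromatic carbon). The two changes are not the same: in compound 1 to compound 3 the exchanged group sits para to a large group, in compound 2 to compound 4 it sits meta to a large group. Going by these compounds, whether the step transfers across that difference in placement is unknown; there is a single measured example.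

On that one example, the step from compound 2 to compound 4 in this assay is expected to be about a 4.6-fold higher number from compound 2 to compound 4 (0.67 log units; beyond the scatter), resting on a 5.1-fold higher number from compound 1 to compound 3 (0.71 log units; beyond the scatter). Compound 4 is therefore estimated at 50000 nM. For compound 4 the expected range runs from 20000 nM to 120000 nM, with a real chance that the assay reports only a limit.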

Compound 4, half-maximal inhibitory concentration: 30100 nM
Estimate against measurement, compound 4: 1.7-fold (0.22 log units) above; the range from low to high includes it.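

In this assay, putting trifluoromethyl in place of the group of five fluorines and one sulfur, here meta to a large group, gives a 2.8-fold higher number from compound 2 to compound 4 (0.45 log units; beyond the scatter), so the second pair moves the same way as the first. Within these two pairs, the change therefore carries from one core to the other in direction, and the two steps cannot be told apart in size: the same change on two cores in this assay, a 5.1-fold higher number (0.71 log units; beyond the scatter) from compound 1 to compound 3 and a 2.8-fold higher number (0.45 log units; beyond the scatter) from compound 2 to compound 4, 1.8-fold (0.26 log units) apart, within the scatter of two such steps. Going by these compounds alone, this rests on only two pairs that share everything except the placement of the exchanged group, so it shows neither that the step would hold on a core differing elsewhere nor what underlies it, and the smaller second step is no evidence that placement alters the step.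

The compounds shown leave open whether the same step would be seen with the hydroxyl group of the shared core replaced by an amine or a carboxylic acid, or with the amide linkage replaced by a longer chain. They also leave open how other groups at these ring positions, such as chlorine, nitrile or tert-butyl, would compare with the two groups exchanged here.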